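Bromine at a New Place on the Phenyl Ring

A few compounds are considered here, and "the series" means these few. Any claim that something is new, unique, unknown or untested is made for them only; others in the source may bear on it.

Compound 1 `NC1=NC2(CCOCC2)N(OCCCOc2ccc(F)cc2)C(N)=N1` gives 3280 nM in a functional assay on HCT-116 cells (Homo sapiens) for antiproliferative activity, read by MTT assay, with a stated time of 72 h (a lower number here means a stronger inhibitor, a higher number a weaker inhibitor), the highest number of the three measured compounds. Compound 2 `NC1=NC2(CCOCC2)N(OCCCOc2ccccc2Br)C(N)=N1` gives 30 nM and compound 3 `COc1ccc(OCCCON2C(N)=NC(N)=NC23CCOCC3)cc1` gives 1500 nM in this assay. The change to compound 4 `NC1=NC2(CCOCC2)N(OCCCOc2cccc(Br)c2)C(N)=N1` is 3-bromophenyl in place of 4-fluorophenyl on an oxygen on a saturated carbon. For the measured compounds named here, two measured steps bear on it: a 110-fold lower number from compound 1 to compound 2 (2.04 log units; beyond the scatter), and a 2.2-fold lower number from compound 1 to compound 3 (0.34 log units; beyond the scatter). Replacing the fluorine has lowered the number each time, and bromine brought the far larger gain, though at a different spot on the ring than in compound 4. A clear drop is therefore expected, yet one smaller than a 110-fold lower number from compound 1 to compound 2 (2.04 log units; beyond the scatter), as the bromine of compound 4 is not at the same spot. Compound 4 is estimated at 300 nM in this assay, within a range from 60 nM to 1500 nM. That estimate means a step of an 11-fold lower number from compound 1 to compound 4 (1.04 log units; beyond the scatter).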

Compound 4, half-maximal inhibitory concentration: 40 nM
Compound 4: the middle estimate sits 7.5-fold (0.88 log units) above what was measured; measured number below the stated range.
By their numbers in this assay, from the lowest: compounds 2 and 4 (each within the scatter of the next); then compound 3; then compound 1.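

The two bromine placements cannot be told apart in this assay (a 1.3-fold higher number from compound 2 to compound 4 (0.12 log units; within the scatter)), so among these compounds the bromine does not need to sit where compound 2 carries it. The 3-bromophenyl group also holds a large lead over 4-fluorophenyl (an 82-fold lower number from compound 1 to compound 4 (1.91 log units; beyond the scatter)) and over 4-methoxyphenyl (a 38-fold lower number from compound 3 to compound 4 (1.57 log units; beyond the scatter)). No measurement here explains these differences.

Going by these compounds, it remains open whether bromine itself matters or whether simply moving the substituent away from its place in 4-fluorophenyl and 4-methoxyphenyl does. A chlorine or methyl group in place of the bromine, or a longer chain, could test how far this holds.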